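The source may report more compounds than this note shows. Statements on the series, on what has been measured and on what is new or still open speak of the compounds shown alone.

Compounds measured so far:
- compound 1 (`O=C(/C=C/c1cccnc1)NCCCCCCCc1ccc(S(=O)(=O)Nc2ccccc2)cc1`): 223 nM
- compound 2 (`O=C(/C=C/c1cccnc1)NCCCCCCCc1cccc(S(=O)(=O)Nc2ccccc2)c1`): 598 nM
- compound 3 (`CCc1ccc(NS(=O)(=O)c2cccc(CCCCCCNC(=O)/C=C/c3cccnc3)c2)cc1`): 132 nM

These values all come from a functional assay on HeLa cells (Homo sapiens) for inhibition, read by CCK-8 assay, with a stated time of 72 h; a higher number here means a weaker inhibitor, a lower number a stronger inhibitor. Compound 3 cannot be told apart from compound 1, since their gap lies within the scatter, but its number is clearly lower than that of compound 2.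

Compound 4 (`O=C(/C=C/c1cccnc1)NCCCCCCc1cccc(S(=O)(=O)Nc2ccc(C(F)(F)F)cc2)c1`) has trifluoromethyl in place of ethyl on an aromatic carbon of compound 3: trifluoromethyl in place of ethyl on an aromatic carbon. For the measured compounds named here, no pair of measured compounds differs in just one place, so the data do not show the size of this change directly. A small rise in this assay, within the scatter, is expected. The estimated step is a 1.4-fold higher number from compound 3 to compound 4 (0.13 log units; within the scatter). For compound 4 the estimated value is 180 nM, with an expected range of 70 nM to 450 nM.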

Compound 4, half-maximal inhibitory concentration: 1450 nM
The estimate for compound 4 lay 8.1-fold (0.91 log units) below the measured number; the whole stated range lies below it.
By their numbers in this assay, from the lowest: compounds 3 and 1 (each within the scatter of the next); then compound 2; then compound 4.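

In this assay, the group at this place on the ring clearly matters: trifluoromethyl in place of ethyl, para to a large group, gives an 11-fold higher number from compound 3 to compound 4 (1.04 log units; beyond the scatter). This is the first measured pair that differs in one place, so it gives the first direct size for any single change among these compounds. Nothing available explains why the number rises. Still open, going by these compounds, is whether an amine, a methoxy group or a carboxylic acid at this place would stay close to compound 3, and whether the same swap has as large an effect with a longer chain.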